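A few compounds are considered here, and "the series" means these few. Any claim that something is new, unique, unknown or untested is made for them only; others in the source may bear on it.

Among the measured compounds shown here, the three compounds measured so far share one core and differ only in the ring that hangs from its oxygen. Compound 1 `Cc1nnsc1CO/N=C/c1c(C)nn(C)c1Oc1ccccc1Cl` carries a 2-chlorophenyl there; in a functional assay on Huh-7 cells (Homo sapiens) for inhibition, read by MTT assay, with a stated time of 48 h (a higher number here means a weaker inhibitor, a lower number a stronger inhibitor), compound 1 gives only a limit, > 50000 nM. Compound 2 `Cc1nnsc1CO/N=C/c1c(C)nn(C)c1Oc1ccc(Br)cc1` carries a 4-bromophenyl; in this assay compound 2 gives 11800 nM. Compound 3 `Cc1nnsc1CO/N=C/c1c(C)nn(C)c1Oc1ccc(I)cc1` carries a 4-iodophenyl. In this assay compound 3 again gives only a limit, > 50000 nM. Compound 3 thus stands at the same limit as compound 1 (the limit of > 50000 nM in this assay, at which 2 of the 3 values shown sit), and the step of an at least 4.2-fold higher number from compound 2 to compound 3 (0.62 log units; beyond the scatter) is the only readable one that touches it; the step that the two limits leave unreadable from compound 1 to compound 3 cannot be sized, and the step of an at least 4.2-fold lower number from compound 1 to compound 2 (0.62 log units; beyond the scatter) runs in the opposite direction.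

Compound 4 `Cc1nnsc1CO/N=C/c1c(C)nn(C)c1Oc1ccc(C(C)(C)C)cc1` differs from compound 3 in one place: tert-butyl in place of iodo on an aromatic carbon. For the measured compounds named here, no measured step swaps a halogen for a carbon group, so the only guidance is the step of an at least 4.2-fold higher number from compound 2 to compound 3 (0.62 log units; beyond the scatter) and the fact that none of the three measured rings gave a strong number. On that basis the number for compound 4 is expected to stay near the limit or only a little below it, an expected step of an at least 1.2-fold lower number from compound 3 to compound 4 (0.09 log units; that floor lies within the scatter). The estimate for compound 4 is 40000 nM, within 10000 nM to 100000 nM.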

Compound 4, half-maximal inhibitory concentration: > 50000 nM
Compound 4: a limit, no number; the forecaster's own chance of this, stated with the estimate: 55%; middle value at least 1.2-fold (0.09 log units) from the limit.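

Replacing bromo with tert-butyl on this aromatic carbon gives an at least 4.2-fold higher number from compound 2 to compound 4 (0.62 log units; beyond the scatter), so a carbon group here, like the iodo of compound 3, does not keep the measurable number of compound 2. Compound 3 and compound 4 both give only limits, and the step between them cannot be read, which leaves iodo and tert-butyl unranked against each other. Compound 2 is now the only one of the four with an actual number in this assay, and the rest of the series sits at one ceiling: the limit of > 50000 nM in this assay, at which 3 of the 4 values shown sit.

The compounds shown leave open whether bromo is a special case at this aromatic carbon or whether other groups there, such as a chloro, a methoxy, an amine or a carboxylic acid, would also give a number. As far as these compounds go, it also stays open whether a change elsewhere on the shared core, rather than on this ring, could bring a lower number than that of compound 2.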